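A few compounds are considered here, and "the series" means these few. Any claim that something is new, unique, unknown or untested is made for them only; others in the source may bear on it.

Compound 1 `CC1Cn2c(nc([N+](=O)[O-])c2C#Cc2ccc(CO)cc2)O1` gives 8770 nM
Compound 2 `CC1Cn2c(nc([N+](=O)[O-])c2C#COC2CCCC2)O1` gives 6650 nM

Both numbers come from an ADME assay on CHO cells (Cricetulus griseus) for cytotoxicity, read by MTT assay, with a stated time of 24 h; on this read-out lower numbers stand for higher toxicity in this test and higher numbers for lower toxicity in this test. Compound 2 stands at 6650 nM and shares its place on this short scale with compound 1 , since the two values lie within the usual scatter of each other and cannot be ranked.

The next compound to be tested is compound 3 `CC1Cn2c(nc([N+](=O)[O-])c2C#Cc2ccccc2)O1`. It carries phenyl in place of cyclopentyloxy on a triple-bonded carbon. Within the data shown here, no pair of measured compounds differs in one place only, so the data hold no direct measure of this exchange. Among the measured compounds shown here, the only guide is that compound 1 at 8770 nM and compound 2 at 6650 nM do not separate, although they carry different groups on the triple-bonded carbon. In this assay, no step beyond the scatter is therefore expected, and the direction is left open. The expected change is a 1.1-fold higher number from compound 2 to compound 3 (0.02 log units; within the scatter). For compound 3 the estimated value is 7000 nM, with an expected range from 2800 nM to 18000 nM.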

Compound 3, half-maximal cytotoxic concentration: 3540 nM
Compound 3: the middle estimate sits 2.0-fold (0.30 log units) above what was measured; the measured number falls inside the stated range.
By their numbers in this assay, from the lowest: compounds 3, 2 and 1 (each within the scatter of the next, the first and the last beyond it).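

In this assay, phenyl in place of cyclopentyloxy on a triple-bonded carbon comes to a 1.9-fold lower number from compound 2 to compound 3 (0.27 log units; within the scatter), so this exchange of a non-aromatic ring bound through oxygen for an aromatic ring of carbon only cannot be told apart from repeat measurement. Among these compounds, the first step beyond the scatter lies on the aromatic carbon instead: hydrogen in place of hydroxymethyl comes to a 2.5-fold lower number from compound 1 to compound 3 (0.39 log units; beyond the scatter), a modest step. This shows that the group on that aromatic carbon bears on the read-out, with higher toxicity in this test for compound 3, which lacks the hydroxymethyl, than for compound 1. The compounds shown offer no measured basis for explaining either step.

From the compounds shown here alone, it remains open whether an amine, a carboxylic acid or a methoxy group on that aromatic carbon would give a number closer to that of compound 1 or to that of compound 3. Also open, going by these compounds, is how a longer chain, such as an alkyl chain ending in an amine, would read in place of phenyl or cyclopentyloxy on the triple-bonded carbon.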